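Aryl hydrazone variation on the shared core

This account rests on a few compounds, and the source may have more. Where it says the series, first, only, none or still open, it means among the compounds named here.

Among the compounds with values here, compound 2 `CN(C)CCn1cnnc1-c1cc(Oc2ccc(NC(=O)N/N=C/c3ccc(F)cc3)cc2F)ccn1` gives 2310 nM in a functional assay on U-87MG ATCC cells (Homo sapiens) for cytotoxicity, read by MTT assay, with a stated time of 72 h (on this read-out lower numbers stand for stronger inhibition and higher numbers for weaker inhibition), the lowest of the two numbers so far; the nearest is compound 1 `COc1ccc(/C=N/NC(=O)Nc2ccc(Oc3ccnc(-c4nncn4CCN(C)C)c3)c(F)c2)c(OC)c1OC`, which in this assay gives 7650 nM. Within the data shown here, the one measured step, a 3.3-fold lower number from compound 1 to compound 2 (0.52 log units; beyond the scatter), came with 4-fluorophenyl in place of 2,3,4-trimethoxyphenyl on a carbon with a double bond to nitrogen. Compound 3 `CN(C)CCn1cnnc1-c1cc(Oc2ccc(NC(=O)N/N=C/c3cccc(Br)c3)cc2F)ccn1` carries 3-bromophenyl in place of 4-fluorophenyl on a carbon with a double bond to nitrogen. Among the measured compounds shown here, no measured step bears directly on this change: the single step available swaps a differently substituted phenyl and offers no guide to the size or direction of a halogen exchange of this kind. With nothing in the data pointing either way, the expectation is a step of a 1.1-fold higher number from compound 2 to compound 3 (0.03 log units; within the scatter), within the scatter. Compound 3 is therefore estimated at 2500 nM in this assay, with a range from 900 nM to 7000 nM.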

Compound 3, half-maximal inhibitory concentration: 830 nM
Compound 3: middle estimate off by 3.0-fold (0.48 log units), on the high side; measured number below the stated range.
By their numbers in this assay, from the lowest: compound 3; then compound 2; then compound 1.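

On the carbon with a double bond to nitrogen, the aryl group still matters in this assay even when little is counted as changing: 3-bromophenyl in place of 4-fluorophenyl, with the same heavy-atom count and no net charge on either group, gives a 2.8-fold lower number from compound 2 to compound 3 (0.44 log units; beyond the scatter), beyond the scatter. Replacing 2,3,4-trimethoxyphenyl with 3-bromophenyl gives a 9.2-fold lower number from compound 1 to compound 3 (0.96 log units; beyond the scatter), the widest span yet seen at this place. No supporting measurement accounts for either step.

The halogen and its place on the ring change together in compound 3, so the compounds shown cannot separate the two; 4-bromophenyl and 3-fluorophenyl would divide that step. Also open, on these data alone, is how a phenyl carrying an amine or a carboxylic acid would read here.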